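Swapping the ester of compound 2 for a morpholine amide

This account rests on a few compounds, and the source may have more. Where it says the series, first, only, none or still open, it means among the compounds named here.

Compound 2 `COC(=O)/C=C/c1ccncc1-c1ccc2ccccc2c1` stands highest of the two numbers in an assay on a protein complex for inhibition of CDK8/Cyclin C (Homo sapiens), with a stated time of 1 h, tested at 10 uM (on this read-out lower numbers stand for less inhibition and higher numbers for more inhibition at the one concentration tested (going by the name of the read-out)), giving 102%. Among the compounds with values here, its nearest neighbour, compound 1 `O=C(O)[C@@H]1CCCN1C(=O)/C=C/c1ccncc1-c1ccc2ccccc2c1`, gives 67%; the only measured step, a number 35 percentage points higher from compound 1 to compound 2 (beyond the scatter), replaces a 2-carboxypyrrolidin-1-yl with methoxy on a carbonyl carbon. Compound 3 `O=C(/C=C/c1ccncc1-c1ccc2ccccc2c1)N1CCOCC1` differs from compound 2 by morpholin-4-yl in place of methoxy on a carbonyl carbon. That earlier step bears only loosely here, since the group entering now carries no carboxylic acid, so a smaller step than before is expected, downward if any, as a number 17 percentage points lower from compound 2 to compound 3 (beyond the scatter). Compound 3 is therefore estimated at 85%, within 55% to 105%.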

Compound 3, a percentage reported as inhibition, at one concentration (the size of the read-out at that concentration, not a potency): 99%
For compound 3 the middle estimate is 14 percentage points below the measured one, within the range that was stated.
By their numbers in this assay, from the lowest: compound 1; then compounds 3 and 2 (each within the scatter of the next).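

At this carbonyl carbon, a morpholin-4-yl ring takes the place of methoxy with no change that can be read in this assay (a number 3 percentage points lower from compound 2 to compound 3 (within the scatter)). Compound 3 is an amide like compound 1, yet the two stand apart (a number 32 percentage points higher from compound 1 to compound 3 (beyond the scatter)), so the amide link alone does not go with the lower number of compound 1. Nothing at hand gives a reason for either step.

The compounds shown leave open whether plain pyrrolidin-1-yl, without the carboxylic acid, would stand with compound 3 or with compound 1. They also leave open how compound 2 and compound 3 compare in potency, as a single concentration cannot tell.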